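Fluoro Removal in Two Antiproliferative Series

The source may report more compounds than this note shows. Statements on the series, on what has been measured and on what is new or still open speak of the compounds shown alone.

Compound 1, `COc1cc2ncnc(Nc3ccc(F)c(Cl)c3)c2cc1OCCCCC(=O)Nc1ccc(S(N)(=O)=O)cc1`, 5020 nM
Compound 2, `COc1cc2ncnc(Nc3cccc(Cl)c3)c2cc1OCCCCC(=O)Nc1ccc(S(N)(=O)=O)cc1`, 30400 nM
Compound 3, `NS(=O)(=O)c1ccc(NC(=S)Nc2ccc3ncnc(Nc4ccc(F)c(Br)c4)c3c2)cc1`, 18200 nM

Of the compounds shown here, three have been measured in a functional assay on A-431 cells (Homo sapiens) for antiproliferative activity, read by MTT assay, with a stated time of 72 h; on this read-out lower numbers stand for stronger inhibition and higher numbers for weaker inhibition. Going from compound 1 to compound 2, the change hydrogen in place of fluoro on an aromatic carbon gave a 6.1-fold higher number from compound 1 to compound 2 (0.78 log units; beyond the scatter). Compound 3 differs from compound 1 in more than one place, and the difference between the two cores is not broken down here; its number in this assay stands within the scatter of that of compound 2 and beyond the scatter of that of compound 1.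

Compound 4, `NS(=O)(=O)c1ccc(NC(=S)Nc2ccc3ncnc(Nc4cccc(Br)c4)c3c2)cc1`, has not yet been measured. It relates to compound 3 by hydrogen in place of fluoro on an aromatic carbon, the same kind of change as before, though here the place is ortho to a bromo group where earlier it was ortho to a chloro group. Because the step of a 6.1-fold higher number from compound 1 to compound 2 (0.78 log units; beyond the scatter) ran toward a higher number, the same kind of change is expected to move compound 4 in the same direction, but on a different core a somewhat smaller step a 3.3-fold higher number from compound 3 to compound 4 (0.52 log units; beyond the scatter) is expected. Compound 4 is therefore estimated at 60000 nM, with a range from 20000 nM to 180000 nM.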

Compound 4, half-maximal inhibitory concentration: 20700 nM
Estimate against measurement, compound 4: 2.9-fold (0.46 log units) above, within the range that was stated.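

On the second core, hydrogen in place of fluoro gave a 1.1-fold higher number from compound 3 to compound 4 (0.06 log units; within the scatter), so in this assay the two compounds cannot be told apart. The step seen on the first core therefore did not carry over at the same size to the second: the same change on two cores in this assay, a 6.1-fold higher number (0.78 log units; beyond the scatter) from compound 1 to compound 2 and a 1.1-fold higher number (0.06 log units; within the scatter) from compound 3 to compound 4, 5.3-fold (0.73 log units) apart, beyond the scatter of two such steps This rests on a single pair for each core, so it shows that the size of this step depends on its setting in these two pairs, but it does not show which difference between the pairs matters, and the halogen that stays is chloro in compound 2 and bromo in compound 4.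

The compounds shown do not separate the role of that remaining halogen from that of the rest of the core, which also differs in its linking chain and its thiourea. From the compounds shown here alone, what a nitrile or a trifluoromethyl group would give in place of the fluoro group, on either core, also remains open.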